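Chloro in place of hydroxy: compound 2 to compound 3

The source may hold more compounds than are shown below. What is called first, only, known or untested is meant among the compounds shown, and "the series" means these compounds.

Compound 1 `COc1cc(/C=C2\CCC/C(=C\c3cccc(O)c3)C2=O)cc(OC)c1OC` is the parent of this pair. In a functional assay on SW-620 cells (Homo sapiens) for antiproliferative activity, read by MTT assay, with a stated time of 72 h (a higher number here means a weaker inhibitor, a lower number a stronger inhibitor), compound 1 gives only a limit, > 10000 nM. Among the measured compounds shown here, compound 2 `COc1cc(/C=C2\CCC/C(=C\c3ccc(O)c(O)c3)C2=O)cc(OC)c1OC` carries an added hydroxy; in this assay compound 2 gives 3200 nM, the only number in hand. The measured step is an at least 3.1-fold lower number from compound 1 to compound 2 (0.49 log units; beyond the scatter).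

Compound 3 `COc1cc(/C=C2\CCC/C(=C\c3ccc(O)c(Cl)c3)C2=O)cc(OC)c1OC` differs from compound 2 by chloro in place of hydroxy on an aromatic carbon, so 3,4-dihydroxyphenyl becomes 3-chloro-4-hydroxyphenyl. For the measured compounds named here, only the one measured step bears on this, and only partly: the hydroxy that now leaves brought the gain of an at least 3.1-fold lower number from compound 1 to compound 2 (0.49 log units; beyond the scatter), while nothing measured tells what chloro does in its place. The expectation in this assay is therefore a modest rise, a 1.9-fold higher number from compound 2 to compound 3 (0.27 log units; within the scatter), giving back part of that gain, with a limit itself a live possibility. Compound 3 is estimated at 6000 nM in this assay, with a range from 2000 nM to 18000 nM.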

Compound 3, half-maximal inhibitory concentration: 800 nM
The estimate for compound 3 lay 7.5-fold (0.88 log units) above the measured number, and the stated range ends above it.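

In this assay, the place on an aromatic carbon, ortho to a hydroxy group and meta to a large group, does not need the hydroxy of compound 2: chloro, which by count brings no hydrogen-bond donor or acceptor there, gives a 4.0-fold lower number from compound 2 to compound 3 (0.60 log units; beyond the scatter). The earlier pair showed only what the other hydroxy of the 3,4-dihydroxyphenyl group adds, whereas this result shows that the hydroxy already present in compound 1 can be exchanged with a gain, and the whole change of the aryl group amounts to an at least 12-fold lower number from compound 1 to compound 3 (1.09 log units; beyond the scatter). Compound 1 gives only a limit, so that larger step is bounded on one side only: the limit of > 10000 nM in this assay, at which 1 of the 3 values shown sits.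

From the compounds shown here alone, with one halogen at this place, it remains open whether the gain belongs to chloro itself or would also follow with fluoro, bromo, methyl or methoxy in the same position. Going by these compounds, it is also open how much the remaining hydroxy contributes in the 3-chloro-4-hydroxyphenyl group, a question that a 3-chlorophenyl analogue or one with an amine in place of that hydroxy would address.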